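This account rests on a few compounds, and the source may have more. Where it says the series, first, only, none or still open, it means among the compounds named here.

Values in a functional assay on CFPAC-1 cells (Homo sapiens) for antiproliferative activity, read by MTT assay, with a stated time of 72 h (on this read-out lower numbers stand for stronger inhibition and higher numbers for weaker inhibition), for the measured compounds:

compound 1, `O=C1O[C@H]([C@@H](O)Cn2cc(-c3ccc(Br)cc3)nn2)C(OCc2ccccc2)=C1OCc1ccccc1`, gives 5830 nM
compound 2, `CCCCc1cn(C[C@H](O)[C@H]2OC(=O)C(OCc3ccccc3)=C2OCc2ccccc2)nn1`, gives 73200 nM
compound 3, `CCCCCc1ccc(-c2cn(C[C@H](O)[C@H]3OC(=O)C(OCc4ccccc4)=C3OCc3ccccc3)nn2)cc1`, gives 9890 nM

Compound 3 stands second highest of the three numbers; its nearest neighbour is compound 1, the gap a 1.7-fold higher number from compound 1 to compound 3 (0.23 log units; within the scatter) lying within the scatter, while the gap to compound 2 is larger, a 7.4-fold lower number from compound 2 to compound 3 (0.87 log units; beyond the scatter).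

Compound 4, `COc1ccccc1-c1cn(C[C@H](O)[C@H]2OC(=O)C(OCc3ccccc3)=C2OCc2ccccc2)nn1`, is not yet measured. It differs from compound 3 by 2-methoxyphenyl in place of 4-pentylphenyl on an aromatic carbon. For the measured compounds named here, two measured steps bear on this change. The swap of one aryl substituent for another, a 1.7-fold higher number from compound 1 to compound 3 (0.23 log units; within the scatter), stayed within the scatter, which suggests that exchanging substituents on the aryl ring moves the number little. The replacement of a plain chain by an aryl ring, a 7.4-fold lower number from compound 2 to compound 3 (0.87 log units; beyond the scatter), was modest and favourable; compound 4 keeps an aryl ring, so that step does not argue for a loss. Going by the values given here, no measured step addresses a methoxy group or this substitution pattern, so the direction is open. On these grounds the step of a 1.2-fold lower number from compound 3 to compound 4 (0.09 log units; within the scatter) is expected to stay within the scatter. Compound 4 is therefore estimated at 8000 nM in this assay, with a range of 2500 nM to 25000 nM.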

Compound 4, half-maximal inhibitory concentration: > 100000 nM
Compound 4: only a limit was reported (the forecaster's own chance of this, stated with the estimate: 5%); middle value at least 12-fold (1.09 log units) from the limit.
By their numbers in this assay, from the lowest: compounds 1 and 3 (each within the scatter of the next); then compound 2. At a limit, above all of these: compound 4.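

In this assay, compound 4 is reported only as a limit, not as a number: the limit of > 100000 nM in this assay, at which 1 of the 4 values shown sits. Read against that limit, an at least 10-fold higher number from compound 3 to compound 4 (1.00 log units; beyond the scatter) and an at least 17-fold higher number from compound 1 to compound 4 (1.23 log units; beyond the scatter) show that an aryl ring on this aromatic carbon does not by itself keep the activity, and that exchanging aryl groups here can matter far more than the near-equal pair of 4-bromophenyl and 4-pentylphenyl suggested. Against the butyl chain, the step of an at least 1.3-fold higher number from compound 2 to compound 4 (0.13 log units; that floor lies within the scatter) has a floor within the scatter, so the gain seen on going from butyl to 4-pentylphenyl does not carry over to 2-methoxyphenyl on this evidence.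

The change from 4-pentylphenyl to 2-methoxyphenyl alters both the substituent and where it sits on the aryl ring, and the compounds shown cannot separate these two parts of the change. As far as these compounds go, how a plain phenyl, a hydroxyl or an amine on the aryl ring would read here stays open, as does the true size of all three steps to compound 4, of which only floors are known.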